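A few compounds are considered here, and "the series" means these few. Any claim that something is new, unique, unknown or untested is made for them only; others in the source may bear on it.

Measured so far:
compound 1 `COc1ccc(CNc2cc(OC)c(OC)c(OC)c2)cc1[N+](=O)[O-]` — 16800 nM
compound 2 `C/C=C/C(=O)N(Cc1cc(OC)c(OC)c(OC)c1)c1ccc(OC)c(O)c1` — 9160 nM
compound 3 `C=C(C)C(=O)N(Cc1ccc(OC)c(O)c1)c1cc(OC)c(OC)c(OC)c1` — 200 nM

In a functional assay on KYSE-450 cells (Homo sapiens) for inhibition, read by MTT assay, with a stated time of 48 h (on this read-out higher numbers stand for weaker inhibition and lower numbers for stronger inhibition), compound 3 stands lowest of the three numbers. The nearest number is that of compound 2, and the gap between the two lies beyond the usual scatter; compound 1 lies furthest off, again beyond the scatter. Within the data shown here, no pair among the measured compounds differs in one place only, so no single step has been quantified in this assay, and the other two values can be read only as what they show.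

Compound 4 `COc1ccc(CN(C(=O)C[Se]C#N)c2cc(OC)c(OC)c(OC)c2)cc1O` is the next compound to be measured in this assay. Relative to compound 3 the change is a group of 4 heavy atoms (2 carbon, 1 nitrogen, 1 selenium; no ring) in place of a group of 3 heavy atoms (3 carbon; no ring), on a carbonyl carbon

Among the measured compounds shown here, no measured step in this assay resembles this change, so the expectation rests on compound 3 alone, whose value 200 nM is the only anchor. The estimated step of a 3.0-fold higher number from compound 3 to compound 4 (0.48 log units; beyond the scatter) is a modest move towards a higher number, somewhat beyond the scatter, with wide uncertainty. Compound 4 is accordingly expected to give about 600 nM in this assay, within a range of 150 nM to 3000 nM.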

Compound 4, half-maximal inhibitory concentration: 280 nM
Estimate against measurement, compound 4: 2.1-fold (0.33 log units) above; the measured number falls inside the stated range.
By their numbers in this assay, from the lowest: compounds 3 and 4 (each within the scatter of the next); then compounds 2 and 1 (each within the scatter of the next).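

In this assay, among these compounds, the first step measured at a single place gives a 1.4-fold higher number from compound 3 to compound 4 (0.15 log units; within the scatter), so on a carbonyl carbon whose other neighbour is the amide-type nitrogen, the selenium-bearing nitrile group reads the same as 1-methylethenyl within the scatter. For this pair, a double bond outside aromatic rings is therefore not needed for a number in this range, since compound 4 carries a triple bond instead. No measurement at hand accounts for the two groups reading alike.

On these data alone, whether sulfur in place of the selenium, or a plain methyl on the carbonyl carbon, would read the same remains open. Compound 2, at 9160 nM, differs from compound 3 in more than one place, so its value cannot be set against this step.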